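Swapping Furan-3-yl for Phenyl on an Aromatic Nitrogen

The source may report more compounds than this note shows. Statements on the series, on what has been measured and on what is new or still open speak of the compounds shown alone.

Two compounds share one core and differ only in the group attached to an aromatic nitrogen. Compound 1 `CCOC(=O)c1ccc(-c2nn(Cc3ccccc3F)c3ccccc23)cc1` carries a 2-fluorobenzyl group there. In a functional assay on cells (Platelet, Homo sapiens) for inhibition (a lower number here means a stronger inhibitor, a higher number a weaker inhibitor), compound 1 gives only a limit, > 10000 nM. Compound 2 `CCOC(=O)c1ccc(-c2nn(-c3ccoc3)c3ccccc23)cc1` carries furan-3-yl instead. In this assay compound 2 likewise gives only a limit, > 10000 nM. The step that the two limits leave unreadable from compound 1 to compound 2 cannot be sized, since (the limit of > 10000 nM in this assay, at which 2 of the 2 values shown sit). Compound 3 `CCOC(=O)c1ccc(-c2nn(-c3ccccc3)c3ccccc23)cc1` is not yet measured; it differs from compound 2 by phenyl in place of furan-3-yl on an aromatic nitrogen. Among the compounds with values here, no measured step shows what phenyl does in this place, and the one change already measured on this nitrogen, from compound 1 to compound 2, left both values at the limit, so no direction can be read from it. Expected for this change is a step that the limit leaves unreadable from compound 2 to compound 3, a step that may well leave the value at a limit again. Compound 3 is estimated at 15000 nM, within a range from 4000 nM to 60000 nM.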

Compound 3, half-maximal inhibitory concentration: > 10000 nM
Compound 3: a limit, no number (the forecaster's own chance of this, stated with the estimate: 80%); the middle value does not contradict the limit.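

Within the data shown here, compound 3 also gives only a limit, so no step among compound 1, compound 2 and compound 3 can be sized: the limit of > 10000 nM in this assay, at which 3 of the 3 values shown sit. The compounds shown leave open how compound 1, compound 2 and compound 3 truly rank in this assay, and whether any group on this nitrogen gives a measurable value there.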